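The source may hold more compounds than are shown below. What is called first, only, known or untested is meant among the compounds shown, and "the series" means these compounds.

Compound 1 `COc1cc2c(NCC3CCN(c4ncc(C(=O)NO)cn4)CC3)cc(-c3ccc(C)o3)nc2cc1OCCCN1CCCC1` carries its hydroxamic acid on a 5-(hydroxycarbamoyl)pyrimidin-2-yl group attached to the ring nitrogen of a piperidine. Going by the values given here, in an assay on isolated protein for inhibition of protein deacetylase HDAC6 (Homo sapiens), read by fluorescence, with a stated time of 30 min (on this read-out higher numbers stand for weaker inhibition and lower numbers for stronger inhibition), compound 1 gives 152 nM, the highest of the two numbers recorded, with compound 2 `COc1cc2c(NCC3CCC(C(=O)NO)CC3)cc(-c3ccc(C)o3)nc2cc1OCCCN1CCCC1` as its only neighbour. In this assay compound 2 gives 34 nM, a lower number than that of compound 1 by a gap that lies beyond the scatter of repeated measurements.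

Compound 3 `COc1cc2c(NCC3CCN(Cc4ccc(C(=O)NO)cc4)CC3)cc(-c3ccc(C)o3)nc2cc1OCCCN1CCCC1` has not yet been measured. It differs from compound 1 in one place: 4-(hydroxycarbamoyl)benzyl in place of 5-(hydroxycarbamoyl)pyrimidin-2-yl on an amine nitrogen in a ring. The shared core, the furyl group and the pyrrolidinylpropoxy chain remain unchanged.

Among the compounds with values here, no measured pair shows this exact exchange, so the size of the step is uncertain. Still, compound 2 reaches 34 nM with a different carrier of the hydroxamic acid, which suggests that the shared core can support stronger inhibition than compound 1 shows. Compound 3 is therefore expected to give a lower number than compound 1, a step of a 3.8-fold lower number from compound 1 to compound 3 (0.58 log units; beyond the scatter) in this assay. Compound 3 is estimated at 40 nM, within a range from 10 nM to 160 nM.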

Compound 3, half-maximal inhibitory concentration: 53 nM
Compound 3: the middle estimate sits 1.3-fold (0.12 log units) below what was measured, and the stated range covers the measured number.
By their numbers in this assay, from the lowest: compounds 2 and 3 (each within the scatter of the next); then compound 1.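

Going by these compounds alone, on the amine nitrogen in a ring, 4-(hydroxycarbamoyl)benzyl in place of 5-(hydroxycarbamoyl)pyrimidin-2-yl gives a 2.9-fold lower number from compound 1 to compound 3 (0.46 log units; beyond the scatter) in this assay, a modest step and the first direct reading of a change at this position. It shows that, with the shared core, the furyl group and the pyrrolidinylpropoxy chain held constant, the group carrying the hydroxamic acid on this nitrogen affects the number, and that a benzyl group is tolerated there. The exchange replaces a ring with 2 hetero atoms by a ring of carbon only and also alters the link to the nitrogen, and no measurement shown here explains the step or assigns it to either part of the exchange.

The compounds shown leave open whether the ring or the link accounts for the step, which a phenyl ring attached directly to that nitrogen, or a pyrimidine ring held on a methylene link, could help to separate. They also leave open how a longer chain between the nitrogen and the ring, or a carboxylic acid in place of the hydroxamic acid, would read in this assay.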